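Swapping a Benzyl for a Benzoyl on a Ring Amine

The source may report more compounds than this note shows. Statements on the series, on what has been measured and on what is new or still open speak of the compounds shown alone.

Compound 1, `NC(=O)c1ccc2[nH]c(-c3ccc(OCCC4CCCCN4Cc4ccc(Cl)cc4)cc3)nc2c1`, in a physicochemical assay for solubility, with a stated time of 3 days, at pH 2 (a lower number here means a less soluble compound, a higher number a more soluble compound), compound 1 gives > 400000 nM, which is a limit of the assay rather than a number.
Compound 2, `NC(=O)c1ccc2[nH]c(-c3ccc(OCCC4CCN(Cc5ccc(Cl)cc5)CC4)cc3)nc2c1`, in this assay compound 2 gives 179000 nM.
Compound 3, `NC(=O)c1ccc2[nH]c(-c3ccc(OCCC4CCCCN4C(=O)c4ccccc4)cc3)nc2c1`, in this assay compound 3 gives 28000 nM.

All three share the same core and differ only in the saturated ring that carries the amine nitrogen and in what sits on that nitrogen. Compound 1 and compound 2 have the same atoms joined differently; the difference between the two cores is not broken down here. Of the two, compound 2 stands with the highest number among the plain numbers, and compound 1 sits at the limit of > 400000 nM in this assay, at which 1 of the 3 values shown sits.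

Within the data shown here, the one change that has been measured is benzoyl in place of 4-chlorobenzyl on an amine nitrogen in a ring. It gave an at least 14-fold lower number from compound 1 to compound 3 (1.15 log units; beyond the scatter). Because compound 1 sits at the limit of > 400000 nM in this assay, at which 1 of the 3 values shown sits, the true size of that step is only known as a lower bound.

Compound 4, `NC(=O)c1ccc2[nH]c(-c3ccc(OCCC4CCN(C(=O)c5ccccc5)CC4)cc3)nc2c1`, has not yet been measured in this assay. It arises from compound 2 by benzoyl in place of 4-chlorobenzyl on an amine nitrogen in a ring. Among the measured compounds shown here, this is the same kind of change as the one from compound 1 to compound 3, though the place differs: in compound 3 the nitrogen is "next to the ring atom that bears a large group", whereas in compound 4 it is "three ring bonds from the ring atom that bears a large group". The expectation for compound 4 rests on that measured step, so a drop of about a 9.0-fold lower number from compound 2 to compound 4 (0.95 log units; beyond the scatter) is expected. Compound 4 is therefore estimated at 20000 nM, with a likely range from 6000 nM to 60000 nM.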

Compound 4, solubility: 3000 nM
The estimate for compound 4 lay 6.7-fold (0.82 log units) above the measured number, and the stated range ends above it.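

Benzoyl in place of 4-chlorobenzyl on the ring nitrogen gave, in this assay, a 60-fold lower number from compound 2 to compound 4 (1.78 log units; beyond the scatter), so the direction seen earlier, an at least 14-fold lower number from compound 1 to compound 3 (1.15 log units; beyond the scatter), held on a second core. The sizes of these two steps cannot be set against each other, and it cannot be said that the change counts for more on one core than on the other, because compound 1 sits at a limit and not at a number: the limit of > 400000 nM in this assay, at which 1 of the 4 values shown sits. Among these compounds, these two pairs show only that the same swap pointed the same way twice; they do not show that it would point that way, or by a similar amount, on any further core, and they give no reason for the drop.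

From the compounds shown here alone, the swap also changes two things at once, since the chlorine leaves and a carbonyl enters, so how much of each step belongs to either one stays open. Going by these compounds, a plain benzyl or a 4-chlorobenzoyl group on that nitrogen would be needed to pull the two apart, and what a small group such as acetyl would give on either core is also open.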